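A few compounds are considered here, and "the series" means these few. Any claim that something is new, unique, unknown or untested is made for them only; others in the source may bear on it.

For the measured compounds named here, compound 1 `CC[C@@H](Nc1c(C#N)c(-c2ccc(-c3ccncc3C)cc2)nc2cnccc12)C(N)=O` is one of two compounds measured in a physicochemical assay for lipophilicity, read by HPLC, at pH 7.5; on this read-out lower numbers stand for lower lipophilicity and higher numbers for higher lipophilicity. In this assay compound 1 gives 2, and compound 2 `CCOc1ccccc1-c1ccc(-c2nc(NC(C)C(=O)O)c3ccncc3n2)cc1` gives 2.1; these two values sit within the usual scatter of each other, so neither can be called the lower one. Compound 3 `CC[C@@H](Nc1c(C#N)c(-c2ccc(-c3ccccc3OC)cc2)nc2cnccc12)C(N)=O` has not yet been measured. It differs from compound 1 in one place: 2-methoxyphenyl in place of 3-methylpyridin-4-yl on an aromatic carbon. Going by the values given here, no pair of measured compounds shows what such a change does, so the expectation rests on the change itself. An upward step of a number 0.80 log units higher from compound 1 to compound 3 (beyond the scatter) beyond the scatter is expected. Compound 3 is therefore estimated at 2.8, most likely between 2.3 and 3.4.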

Compound 3, distribution coefficient: 2.7
For compound 3 the middle estimate is 0.10 log units above the measured one; measured number inside the range.
By their numbers in this assay, from the lowest: compounds 1 and 2 (each within the scatter of the next); then compound 3.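

For the compounds shown here, putting 2-methoxyphenyl in place of 3-methylpyridin-4-yl gives the first measured step at this position in this assay, with a rise of a number 0.70 log units higher from compound 1 to compound 3 (beyond the scatter), so this change on the aromatic carbon moves the read-out. The counts of hydrogen-bond donors and acceptors are the same in the two groups, so those counts alone do not track this step. No measurement on hand explains the rise.

Whether the ring nitrogen, the methyl or the methoxy group accounts for the step stays open, and a plain phenyl group here would help separate them. From the compounds shown here alone, how an amine or a carboxylic acid on this ring would read also stays open.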